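This account rests on a few compounds, and the source may have more. Where it says the series, first, only, none or still open, it means among the compounds named here.

The measured compounds:
In an assay on isolated protein for inhibition of Gonadotropin-releasing hormone receptor (Homo sapiens) (a lower number here means a stronger inhibitor, a higher number a weaker inhibitor), compound 1 `CCCn1c(SCc2cc([N+](=O)[O-])ccc2OC)nc2cc(NC(=O)NC(C)(C)C)ccc21` gives 18 nM.
In this assay compound 2 `CCCCn1c(SCc2cc([N+](=O)[O-])ccc2OC)nc2cc(NC(=O)NC(C)(C)C)ccc21` gives 23 nM.
In this assay compound 3 `COc1ccc([N+](=O)[O-])cc1CSc1nc2cc(NC(=O)NC(C)(C)C)ccc2n1Cc1ccccc1` gives 28 nM.

Compound 3 carries the highest of the three numbers, yet its distance from compound 2 is a 1.2-fold higher number from compound 2 to compound 3 (0.09 log units; within the scatter) and its distance from compound 1 is a 1.6-fold higher number from compound 1 to compound 3 (0.19 log units; within the scatter), both within the scatter, so the three compounds cannot be told apart on these data.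

The step from compound 3 to compound 4 `COc1ccc([N+](=O)[O-])cc1CSc1nc2cc(NC(=O)NC(C)(C)C)ccc2n1-c1ccccc1` is phenyl in place of benzyl on an aromatic nitrogen. For the measured compounds named here, no measured pair makes exactly this exchange. Going by the values given here, the steps that bear on it are those that swap one substituent on the same ring nitrogen for another: a 1.3-fold higher number from compound 1 to compound 2 (0.11 log units; within the scatter), a 1.6-fold higher number from compound 1 to compound 3 (0.19 log units; within the scatter) and a 1.2-fold higher number from compound 2 to compound 3 (0.09 log units; within the scatter), each within the scatter. Three different substituents on that nitrogen have thus left the number essentially where it was, and compound 4 keeps an aromatic ring at that position. For compound 4 the expected step of a 1.3-fold higher number from compound 3 to compound 4 (0.10 log units; within the scatter) is therefore small, with at most a slight drift toward a higher number and no change beyond the scatter firmly predicted. Compound 4 is estimated at 35 nM, within a range from 12 nM to 110 nM.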

Compound 4, half-maximal inhibitory concentration: 350 nM
Compound 4: middle estimate off by 10-fold (1.00 log units), on the low side; measured number outside the range, above it.
By their numbers in this assay, from the lowest: compounds 1, 2 and 3 (each within the scatter of the next); then compound 4.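

In this assay, for the compounds shown here, propyl, butyl and benzyl on the aromatic nitrogen of the five-membered ring had stayed within the scatter of one another, so the position looked open to exchange; phenyl is the first group there to move the number, giving a 13-fold higher number from compound 3 to compound 4 (1.10 log units; beyond the scatter) and a 15-fold higher number from compound 2 to compound 4 (1.18 log units; beyond the scatter) and a 19-fold higher number from compound 1 to compound 4 (1.29 log units; beyond the scatter). The exchange of benzyl for phenyl keeps the six-membered aromatic ring of carbon and takes away only one carbon, so an aromatic ring at this position does not by itself hold the number where it was: compounds 1, 2 and 3 all have a saturated chain carbon bound to that nitrogen, and compound 4 alone lacks it. Nothing measured here bears on the reason for this jump.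

Still open, from the compounds shown here alone, is whether the rise follows from an aromatic ring bound directly to the nitrogen or from the lack of a saturated carbon there, a question that a cyclohexyl, a methyl or a phenethyl group on that nitrogen would help to separate. Also open, going by these compounds, is whether a directly attached pyridyl ring, or a phenyl ring carrying a methoxy group or a fluorine, would stay at the level of compound 4.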